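Shifting the Methyl Group: From Compound 1 to Compound 3

This account rests on a few compounds, and the source may have more. Where it says the series, first, only, none or still open, it means among the compounds named here.

Measured compounds:
- Compound 1, `C=CCn1c(=O)/c(=C\c2cccc(C)c2)[nH]c(=O)/c1=C\c1ccccc1OC`, gives 16700 nM
- Compound 2, `C=CCn1c(=O)/c(=C\c2ccccc2F)[nH]c(=O)/c1=C\c1ccccc1OC`, gives 18500 nM

Both values come from a functional assay on HL-60 cells (Homo sapiens) for cytotoxicity, read by CCK-8 assay, with a stated time of 72 h; a higher number here means a weaker inhibitor, a lower number a stronger inhibitor. Among the two numbers, compound 1 has the lower one, and compound 2 stands nearest to it; the gap is within the usual scatter, so no order between them can be claimed. Among the measured compounds shown here, the single measured step, a 1.1-fold higher number from compound 1 to compound 2 (0.04 log units; within the scatter), swapped the group on a double-bonded chain carbon bound to an aromatic carbon and did not move the number beyond the scatter.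

Compound 3, `C=CCn1c(=O)/c(=C\c2ccc(C)cc2)[nH]c(=O)/c1=C\c1ccccc1OC`, is not yet measured. It differs from compound 1 in the same place: 4-methylphenyl in place of 3-methylphenyl on a double-bonded chain carbon bound to an aromatic carbon. For the measured compounds named here, the measured step is the only guide here, and it showed that changing the group at this position, even to a different substituent entirely, left the number essentially where it was. A smaller change, keeping the methyl group and only placing it differently on the same ring, is therefore expected to produce no step beyond the scatter.

For compound 3 the expected value is 17000 nM, with a range from 8500 nM to 34000 nM. The expected step is a 1.0-fold higher number from compound 1 to compound 3 (0.01 log units; within the scatter), which amounts to no change beyond the scatter.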

Compound 3, half-maximal inhibitory concentration: "not active" (no number reported)
The entry for compound 3 holds no number; no gap can be computed for the estimate.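

In this assay, among the compounds shown here, compound 3 is recorded as "not active" with no number, so no step from compound 1 to compound 3 can be read. No measured evidence on hand bears on this result. The compounds shown leave open whether 4-methylphenyl in place of 3-methylphenyl truly weakens the compound, and by how much.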